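Sulfonyl to carbamate: solubility expectation for compound 3

This account rests on a few compounds, and the source may have more. Where it says the series, first, only, none or still open, it means among the compounds named here.

Compound 1 `O=C1O[C@@H](CO)CN1c1ccc(-n2cc(-c3ccccn3)cn2)c(F)c1` and compound 2 `CS(=O)(=O)NC[C@H]1CN(c2ccc(-n3cc(-c4ccccn4)cn3)c(F)c2)C(=O)O1` share one core and differ only in the side chain. In a physicochemical assay for solubility, read by HPLC, with a stated time of 24 h (a lower number here means a less soluble compound, a higher number a more soluble compound), compound 1 gives 56400 nM, while compound 2 gives 2300 nM. For the measured compounds named here, the single measured step, a 25-fold lower number from compound 1 to compound 2 (1.39 log units; beyond the scatter), is the only one so far. Compound 2 therefore stands at the lower of the two numbers, with compound 1 as its nearest and higher neighbour. Compound 3 `COC(=O)NC[C@H]1CN(c2ccc(-n3cc(-c4ccccn4)cn3)c(F)c2)C(=O)O1` is not yet measured; it differs from compound 2 by methoxycarbonyl in place of methylsulfonyl on an amine nitrogen. Going by the values given here, no measured step bears directly on this change: the one step known, hydroxy to methanesulfonamido, alters a different part of the chain, and both compound 2 and compound 3 keep a substituted amine nitrogen at that position. The expected step for compound 3 in this assay is a 1.1-fold higher number from compound 2 to compound 3 (0.04 log units; within the scatter), nothing beyond the scatter in either direction. Compound 3 is estimated at 2500 nM, with a range of 700 nM to 9000 nM.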

Compound 3, solubility: 34100 nM
The estimate for compound 3 lay 14-fold (1.13 log units) below the measured number, and the stated range ends below it.
By their numbers in this assay, from the lowest: compound 2; then compounds 3 and 1 (each within the scatter of the next).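

In this assay the exchange on the amine nitrogen is far from neutral, with a 15-fold higher number from compound 2 to compound 3 (1.17 log units; beyond the scatter), so a substituted amine nitrogen at this position does not by itself go with a low number. Replacing the hydroxy group on the saturated chain carbon gives two different outcomes: a 25-fold lower number from compound 1 to compound 2 (1.39 log units; beyond the scatter) for methanesulfonamido, but a 1.7-fold lower number from compound 1 to compound 3 (0.22 log units; within the scatter) for (methoxycarbonyl)amino, so among these three compounds only compound 2, the one carrying methylsulfonyl, stands apart from the other two. Nothing available here gives a reason for this difference between methylsulfonyl and methoxycarbonyl.

Still open, from the compounds shown here alone, is where other groups on the same nitrogen would fall, such as an acetyl group, an ethoxycarbonyl group or a longer sulfonyl chain such as ethylsulfonyl, and whether the free amine would stay with compound 1 and compound 3 or fall nearer compound 2. The compounds shown also leave open whether the gap between methylsulfonyl and methoxycarbonyl holds on any core other than the shared one.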